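The source may report more compounds than this note shows. Statements on the series, on what has been measured and on what is new or still open speak of the compounds shown alone.

Measured in a functional assay on cells (Homo sapiens) for antiproliferative activity, read by MTT assay, with a stated time of 48 h; a lower number here means a stronger inhibitor, a higher number a weaker inhibitor:
- Compound 1 `CN(C)CCCn1c(N)c(-c2nc3ccccc3[nH]2)c2nc(C#N)c(C#N)nc21`: 1820 nM
- Compound 2 `CN(C)CCCn1c(N)c(-c2nc3ccccc3o2)c2nc(C#N)c(C#N)nc21`: 5640 nM
- Compound 3 `CN(C)CCn1c(N)c(-c2nc3ccccc3s2)c2nc(C#N)c(C#N)nc21`: > 50000 nM

Compound 3 is the only one of the three without a number: its > 50000 nM is a limit.

Compound 4 `CN(C)CCCn1c(N)c(-c2nc3ccccc3s2)c2nc(C#N)c(C#N)nc21` keeps the ring group of compound 3 and alters only the side chain: (dimethylamino)methyl in place of dimethylamino on a saturated chain carbon, two bonds along the chain from an aromatic nitrogen. In other words, 2-(dimethylamino)ethyl becomes 3-(dimethylamino)propyl.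

Among the compounds with values here, no measured step covers this chain change directly. Within the data shown here, the one measured step, a 3.1-fold higher number from compound 1 to compound 2 (0.49 log units; beyond the scatter), is modest and concerns the ring group instead. Still, it links the two compounds that already carry the longer chain, compound 1 at 1820 nM and compound 2 at 5640 nM. A large fall in the number is therefore expected, in the same range as those two. The expected step is an at least 8.3-fold lower number from compound 3 to compound 4 (0.92 log units; beyond the scatter), and its size is loose, as it starts from a limit. For compound 4 the estimated value is 6000 nM, with an expected range of 1800 nM to 25000 nM.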

Compound 4, half-maximal inhibitory concentration: 2930 nM
Compound 4: middle estimate off by 2.0-fold (0.31 log units), on the high side, within the range that was stated.
By their numbers in this assay, from the lowest: compounds 1, 4 and 2 (each within the scatter of the next, the first and the last beyond it). At a limit, above all of these: compound 3.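

In this assay, changing 2-(dimethylamino)ethyl to 3-(dimethylamino)propyl on the same ring group gives an at least 17-fold lower number from compound 3 to compound 4 (1.23 log units; beyond the scatter), so this chain position clearly matters in the benzothiazolyl compounds. The value of compound 3 is a limit, so the size of that step is only a minimum: the limit of > 50000 nM in this assay, at which 1 of the 4 values shown sits. With the longer chain, the ring group changes little for compound 4, as a 1.9-fold lower number from compound 2 to compound 4 (0.28 log units; within the scatter) and a 1.6-fold higher number from compound 1 to compound 4 (0.21 log units; within the scatter) both stay within the scatter.

From the compounds shown here alone, whether a longer chain, such as 4-(dimethylamino)butyl, would do as well remains open, as does the effect of a piperidine at the chain end. Also open, going by these compounds, is whether the 2-(dimethylamino)ethyl chain has as large an effect with the 1H-benzimidazol-2-yl group.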